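Moving the methoxy group on the aryl substituent

A few compounds are considered here, and "the series" means these few. Any claim that something is new, unique, unknown or untested is made for them only; others in the source may bear on it.

Measured compounds:
compound 1 `COc1cccc(-c2cn(C)c(=O)c3[nH]c(C(=O)NCc4ccc(C(=O)Nc5ccccc5N)cc4)cc23)c1` gives 250 nM
compound 2 `Cn1cc(-c2ccccc2Oc2ccccc2)c2cc(C(=O)NCCCCC(=O)NO)[nH]c2c1=O` gives 180 nM

In a functional assay on MV4-11 cells (Homo sapiens) for antiproliferative activity, read by CCK-8 assay, with a stated time of 72 h (on this read-out higher numbers stand for weaker inhibition and lower numbers for stronger inhibition), compound 1 has the highest of the two numbers; compound 2 lies a short distance away, within the usual scatter, so no order between them can be claimed. Compound 3 `COc1ccccc1-c1cn(C)c(=O)c2[nH]c(C(=O)NCc3ccc(C(=O)Nc4ccccc4N)cc3)cc12` differs from compound 1 in one place: 2-methoxyphenyl in place of 3-methoxyphenyl on an aromatic carbon. Going by the values given here, no measured pair shows what such a change does here, so the expectation rests on compound 1 alone. The step of a 1.2-fold higher number from compound 1 to compound 3 (0.08 log units; within the scatter) is expected to stay within the scatter. Compound 3 is therefore estimated at 300 nM, with a range from 110 nM to 900 nM.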

Compound 3, half-maximal inhibitory concentration: 200 nM
The estimate for compound 3 lay 1.5-fold (0.18 log units) above the measured number; the range from low to high includes it.
By their numbers in this assay, from the lowest: compounds 2, 3 and 1 (each within the scatter of the next).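

In this assay the step on replacing 3-methoxyphenyl with 2-methoxyphenyl is a 1.3-fold lower number from compound 1 to compound 3 (0.10 log units; within the scatter) and so the two placements of the methoxy group cannot be told apart at this aromatic carbon of the shared core. Going by these compounds alone, this pair gives the first one-place comparison at this position. Nothing available explains this result.

The compounds shown leave open how 4-methoxyphenyl would compare with compound 1 and compound 3. They also leave open whether an amine or a carboxylic acid in place of the methoxy group would keep the number in this range.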